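Compound 3, the only measured number in this series

This account rests on a few compounds, and the source may have more. Where it says the series, first, only, none or still open, it means among the compounds named here.

Measured so far in a functional assay on DU-145 cells (Homo sapiens) for cytotoxicity, read by MTT assay; a lower number here means a stronger inhibitor, a higher number a weaker inhibitor (the first two values are limits, not numbers):

- compound 1 `CC(C)=CC[C@@H](OC(=O)c1ccco1)C1=CC(=O)c2c(O)ccc(O)c2C1=O` with > 100000 nM
- compound 2 `CCCC(O)CC(=O)O[C@H](CC=C(C)C)C1=CC(=O)c2c(O)ccc(O)c2C1=O` with > 100000 nM
- compound 3 `CC(=O)OCCO[C@H](CC=C(C)C)C1=CC(=O)c2c(O)ccc(O)c2C1=O` with 15500 nM

Within the data shown here, compound 3 is the only compound here with a true number (15500 nM). Compound 1 and compound 2 are known only through the limit of > 100000 nM in this assay, at which 2 of the 3 values shown sit, and nothing finer.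

The next compound is compound 4 `CC(C)=CC[C@@H](OCC(C)O)C1=CC(=O)c2c(O)ccc(O)c2C1=O`, which has 1-hydroxyethyl in place of acetoxymethyl on a saturated chain carbon bound to an oxygen on a saturated carbon. The same change reads 2-acetoxyethyl to 2-hydroxypropyl.

Among the measured compounds shown here, two measured steps bear on it, though neither makes this exact change. They are an at least 6.4-fold lower number from compound 1 to compound 3 (0.80 log units; beyond the scatter) and an at least 6.4-fold lower number from compound 2 to compound 3 (0.80 log units; beyond the scatter), and both replace a carbonyl-linked group on that oxygen with 2-acetoxyethyl. Compound 4 also has no carbonyl on that oxygen, so it is expected to keep much of the gain seen in an at least 6.4-fold lower number from compound 2 to compound 3 (0.80 log units; beyond the scatter) and not fall back to the limit.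

Compound 2 does carry a hydroxyl on its chain and reached only a limit (> 100000 nM), which is a reason for caution. A small move towards a higher number is therefore expected, namely a 1.6-fold higher number from compound 3 to compound 4 (0.21 log units; within the scatter) (an estimate).

For compound 4 the estimated value is 25000 nM with an expected range from 7000 nM to 90000 nM (estimated).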

Compound 4, half-maximal inhibitory concentration: 16100 nM
Estimate against measurement, compound 4: 1.6-fold (0.19 log units) above, within the range that was stated.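

In this assay there is a 1.0-fold higher number from compound 3 to compound 4 (0.02 log units; within the scatter) on exchanging acetoxymethyl for 1-hydroxyethyl, so the two chains cannot be told apart here, even though the entering group has fewer heavy atoms and carries a hydrogen-bond donor that the leaving group lacks. The acetoxy end is therefore not needed for the activity of compound 3, and a second chain with no carbonyl on that oxygen also stands clear of the carbonyl-linked compounds, with an at least 6.2-fold lower number from compound 2 to compound 4 (0.79 log units; beyond the scatter) and an at least 6.2-fold lower number from compound 1 to compound 4 (0.79 log units; beyond the scatter) both printed as beyond the scatter. Those two steps give only a minimum size, since compound 1 and compound 2 each sit at a limit and not at a number: the limit of > 100000 nM in this assay, at which 2 of the 4 values shown sit.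

Still open, on these data alone, is whether the hydroxyl of compound 4 matters at all, a question that a plain propyl chain would answer. Also open, as far as these compounds go, is how far this chain can be changed before activity is lost, for instance with an amine or a carboxylic acid at its end, or with a much longer chain.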